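The source may report more compounds than this note shows. Statements on the series, on what has been measured and on what is new or still open speak of the compounds shown alone.

Measured so far:
- compound 1 `CCN(CC)CCCOc1cc2ncnc(Nc3nc4ccc(C(=O)Nc5c(C)cc(C)cc5C)cc4s3)c2cc1OC`: 6800 nM
- compound 2 `COc1cc2c(Nc3nc4ccc(C(=O)Nc5c(C)cccc5Cl)cc4s3)ncnc2cc1OCCCN1CCCCC1`: 14700 nM

In a functional assay on DLD-1 cells (Homo sapiens) for cytotoxicity, read by WST assay, with a stated time of 72 h (a lower number here means a stronger inhibitor, a higher number a weaker inhibitor), compound 2 stands at the highest of the two numbers, while compound 1 gives 6800 nM, lower by a margin beyond the scatter; these two compounds differ in more than one place, so the numbers alone tell nothing about any single change. Compound 3 `COc1cc2c(Nc3nc4ccc(C(=O)Nc5c(C)cc(C)cc5C)cc4s3)ncnc2cc1OCCCN1CCCCC1` differs from compound 2 by 2,4,6-trimethylphenyl in place of 2-chloro-6-methylphenyl on an amide-type nitrogen. Among the measured compounds shown here, no single-change step has been measured here. A modest move toward a lower number, a 1.7-fold lower number from compound 2 to compound 3 (0.24 log units; within the scatter), is expected. Compound 3 is estimated at 8500 nM, within 3000 nM to 22000 nM.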

Compound 3, half-maximal inhibitory concentration: 24500 nM
For compound 3 the middle estimate is 2.9-fold (0.46 log units) below the measured one, outside the stated range (above it).
By their numbers in this assay, from the lowest: compound 1; then compounds 2 and 3 (each within the scatter of the next).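

In this assay the swap of 2-chloro-6-methylphenyl for 2,4,6-trimethylphenyl on the amide-type nitrogen gives a change that cannot be told from repeat-measurement noise (a 1.7-fold higher number from compound 2 to compound 3 (0.22 log units; within the scatter)), so this pair does not separate the two groups. Piperidin-1-yl in place of diethylamino on the saturated chain carbon gives the first clear single-change result (a 3.6-fold higher number from compound 1 to compound 3 (0.56 log units; beyond the scatter)), favouring diethylamino in this one pair. No measurement here explains either result. Still open, as far as these compounds go, is how a morpholine or a 4-methylpiperazine on that chain would read, or an unsubstituted phenyl on the amide-type nitrogen.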